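The source may hold more compounds than are shown below. What is called first, only, known or untested is meant among the compounds shown, and "the series" means these compounds.

Measured so far in a functional assay on U-87MG ATCC cells for antiproliferative activity against U-87 MG (Homo sapiens), read by spectrophotometry, with a stated time of 2 days; on this read-out lower numbers stand for stronger inhibition of growth and higher numbers for weaker inhibition of growth:

Compound 1, `Cc1cc(Cl)ccc1Nc1ncc(C(F)(F)F)c(N2Cc3cccc(N(C)S(C)(=O)=O)c3C2)n1`, gives 28300 nM.
Compound 2, `CN(c1cccc2c1CN(c1nc(Nc3ccc(Cl)c(C(F)(F)F)c3)ncc1C(F)(F)F)C2)S(C)(=O)=O`, gives > 30000 nM, which is a limit of the assay rather than a number.
Compound 3, `COc1ccc(C(F)(F)F)cc1Nc1ncc(C(F)(F)F)c(N2Cc3cccc(N(C)S(C)(=O)=O)c3C2)n1`, gives > 30000 nM, again a limit of the assay.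

Compound 2 therefore stands only at a limit in this assay, and the same holds for compound 3: the limit of > 30000 nM in this assay, at which 2 of the 3 values shown sit. For the measured compounds named here, the one number that does exist, that of compound 1, is itself far from potent. The step is an at least 1.0-fold higher number from compound 1 to compound 2 (0.02 log units; that floor lies within the scatter), and the parallel step is an at least 1.0-fold higher number from compound 1 to compound 3 (0.02 log units; that floor lies within the scatter); between the two limits there is a step that the two limits leave unreadable from compound 2 to compound 3. All three compounds share the same core and differ only in the aryl group on the same nitrogen, and in every case the result sits at or near the floor of the read-out.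

The compound still to be measured is compound 4, `Cc1ccc(Nc2ncc(C(F)(F)F)c(N3Cc4cccc(N(C)S(C)(=O)=O)c4C3)n2)c(C)c1`. It differs from compound 2 in one place: 2,4-dimethylphenyl in place of 4-chloro-3-(trifluoromethyl)phenyl on a nitrogen on an aromatic ring. The measured steps at this position were at most at the floor of the scatter, so no step beyond the scatter is expected in this assay from the new aryl group. The change from compound 2 to compound 4 is expected to be a number no higher from compound 2 to compound 4 (the limit leaves the size open). Compound 4 is therefore estimated to give 30000 nM, with a range of 12000 nM to 70000 nM, and a fair chance that only a limit is reported.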

Compound 4, concentration for 50% growth inhibition: > 30000 nM
Compound 4: a limit, no number; the forecaster's own chance of this, stated with the estimate: 55%; the middle value lies on the limit itself.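

In this assay, methyl in place of chloro on an aromatic carbon gives an at least 1.0-fold higher number from compound 1 to compound 4 (0.02 log units; that floor lies within the scatter), so this exchange on the aryl group of compound 1 yields no readable gain in inhibition of growth. Compound 4 also shows that the limit does not depend on trifluoromethyl or chlorine: 2,4-dimethylphenyl carries only carbon, yet it ends at the same limit as the 4-chloro-3-(trifluoromethyl)phenyl of compound 2 and the 2-methoxy-5-(trifluoromethyl)phenyl of compound 3. The steps from compound 2 and from compound 3 to compound 4 cannot be read, and across these four aryl groups the position gives no measurable spread, with a single number and the rest at one limit: the limit of > 30000 nM in this assay, at which 3 of the 4 values shown sit.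

The compounds shown leave open whether any group on this aryl ring, such as a morpholine, a primary amine or a carboxylic acid, would bring the read-out down to a clearly measurable number. They also leave open whether a change elsewhere on the shared core, for instance an amide in place of the methanesulfonamide, would do more than any change on this nitrogen.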